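Replacing 2-iodophenyl with 2,5-dimethoxyphenyl

The source may report more compounds than this note shows. Statements on the series, on what has been measured and on what is new or still open speak of the compounds shown alone.

In a functional assay on HCT-116 cells (Homo sapiens) for antiproliferative activity, with a stated time of 72 h (a lower number here means a stronger inhibitor, a higher number a weaker inhibitor), compound 1 `CC(=O)Oc1ccccc1/C=C/c1nc2ccccc2c(=O)[nH]1` gives 17200 nM, and compound 3 `CC(=O)Oc1cccc(/C=C/c2nc3ccccc3c(=O)[nH]2)c1` gives 9290 nM. These two values lie within the usual scatter of each other.

Compound 2 `CC(=O)Oc1ccccc1/C=C/c1nc(Nc2ccccc2I)c2ccccc2n1` returned > 25000 nM, which is a limit and not a number, and this is the limit of > 25000 nM in this assay, at which 1 of the 3 values shown sits. So the position of compound 2 is known from one side only, with no exact value to start from.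

Compound 4 `COc1ccc(OC)c(Nc2nc(/C=C/c3ccccc3OC(C)=O)nc3ccccc23)c1` has 2,5-dimethoxyphenyl in place of 2-iodophenyl on a nitrogen on an aromatic ring. Within the data shown here, no measured pair shows what this swap does, so any forecast is loose. Compound 1, at 17200 nM, offers the nearest guide to a likely level, so a number close to it is expected.

A small expected move toward a stronger inhibitor is the forecast, given as an at least 1.5-fold lower number from compound 2 to compound 4 (0.19 log units; that floor lies within the scatter). A reading at the limit again would be no surprise. For compound 4 the estimated value is 16000 nM, with an expected range of 5000 nM to 40000 nM.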

Compound 4, half-maximal inhibitory concentration: > 25000 nM
Compound 4: no number, only a limit (the forecaster's own chance of this, stated with the estimate: 45%); middle value at least 1.5-fold (0.19 log units) from the limit.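

Compound 2 and compound 4 both end at a limit and not at a number, so the step between them cannot be read: the limit of > 25000 nM in this assay, at which 2 of the 4 values shown sit.

The compounds shown leave open whether 2,5-dimethoxyphenyl in place of 2-iodophenyl changes the activity at all, and in which direction.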